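Chloro in place of methoxy: compound 2 to compound 4

This account rests on a few compounds, and the source may have more. Where it says the series, first, only, none or still open, it means among the compounds named here.

Results in a functional assay on BGC-823 cells (Homo sapiens) for cytotoxicity, read by CCK-8 assay, with a stated time of 72 h (a higher number here means a weaker inhibitor, a lower number a stronger inhibitor), so far:
- Compound 1 `C=CCn1c(=O)/c(=C\c2cccc(Cl)c2)[nH]c(=O)/c1=C\c1ccccc1OC` gives 4600 nM
- Compound 2 `COc1ccccc1/C=c1/[nH]c(=O)/c(=C\c2ccccc2OC)n(C)c1=O` gives "not active" (no number reported)
- Compound 3 `COc1ccccc1/C=c1/[nH]c(=O)/c(=C\c2ccccc2OC)[nH]c1=O` gives "not active" (no number reported)

Compound 2 has no single number in this assay to stand on, and compound 3 shares that position. Only compound 1 gives a number, and it differs from compound 2 in more than one place.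

Compound 4 `COc1ccccc1/C=c1\c(=O)[nH]/c(=C/c2ccccc2Cl)c(=O)n1C` is still unmeasured. It follows from chloro in place of methoxy on an aromatic carbon, with chloro in place of methoxy on an aromatic carbon, ortho to a large group. Among the compounds with values here, no measured step fixes the size of this change. The expected direction is towards a measurable value in the region of compound 1 (4600 nM), although another result without a number is quite possible. For compound 4 the estimated value is 10000 nM (expected range 3000 nM to 40000 nM).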

Compound 4, half-maximal inhibitory concentration: 300 nM
Compound 4: the middle estimate sits 33-fold (1.52 log units) above what was measured, and the stated range ends above it.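

Within the data shown here, compound 2 has no number, and no step to compound 4 can be read from it. Going by these compounds, how much the swap from 2-methoxyphenyl to 2-chlorophenyl changes potency stays open. No measurement here offers an explanation for the result.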